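Terminal aryl variation on the shared core of compound 3

A few compounds are considered here, and "the series" means these few. Any claim that something is new, unique, unknown or untested is made for them only; others in the source may bear on it.

Measured compounds:
compound 1 `c1ccc(-c2ccc(CCc3nc(CC4CCCC4)c[nH]3)cc2)nc1` 98 nM
compound 2 `CCC(C)(C)Cc1c[nH]c(CCc2ccc(-c3cccnc3)cc2)n1` 98 nM
compound 3 `CCC(C)(C)Cc1c[nH]c(CCc2ccc(-c3cccc(C#N)n3)cc2)n1` 95 nM

In a functional assay on HEK293 cells for agonist activity at Bombesin receptor subtype-3 (Homo sapiens), read by luminescence and calcium flux, with a stated time of 10 min (a higher number here means that more compound is needed for the effect, a lower number that less compound is needed), compound 3 gives 95 nM, the lowest of the three numbers, though its gaps to compound 1 and compound 2 lie within the scatter, so no order among them can be read. Within the data shown here, the only step on this terminal ring is a 1.0-fold lower number from compound 2 to compound 3 (0.01 log units; within the scatter), within the scatter. Compound 4 `CCC(C)(C)Cc1c[nH]c(CCc2ccc(-c3ccccc3C(=O)O)cc2)n1` carries the change (2-carboxyphenyl in place of 6-cyanopyridin-2-yl on an aromatic carbon). Among the measured compounds shown here, no measured step bears on a carboxyl at this position; that the ring swap so far left the number unchanged argues for little movement, but the new group is less like its predecessor, so the range is set wider. The estimate for compound 4 is 180 nM (range 50 nM to 700 nM), meaning an expected step of a 1.9-fold higher number from compound 3 to compound 4 (0.28 log units; within the scatter).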

Compound 4, half-maximal effective concentration: 101 nM
Beside the measured number, compound 4's estimate is 1.8-fold (0.25 log units) above it; low and high end bracket the measured number.
By their numbers in this assay, from the lowest: compounds 3, 1, 2 and 4 (each within the scatter of the next).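

With a 1.1-fold higher number from compound 3 to compound 4 (0.03 log units; within the scatter) and a 1.0-fold higher number from compound 2 to compound 4 (0.01 log units; within the scatter) both within the scatter in this assay, a 2-carboxyphenyl ring of carbon only stands level with the two pyridine-based groups at this place. The number therefore does not depend on a ring nitrogen or a nitrile among these compounds, and the entering hydrogen-bond donor leaves it unmoved. Nothing measured on these compounds accounts for this flatness.

Open, from the compounds shown here alone, is whether an aliphatic amine or a primary amide on this ring would hold the number, and whether the 2-carboxyphenyl group behaves alike on the core of compound 1.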